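Chloro Enters the Phenyl Group of Compound 3

A few compounds are considered here, and "the series" means these few. Any claim that something is new, unique, unknown or untested is made for them only; others in the source may bear on it.

Compound 3 `Cc1cc(-c2ccccc2)n(Cc2n[nH]c(=S)o2)n1` was tested in a functional assay on the whole organism (strain albino) for inhibition, with Rattus norvegicus as the target, read by paw edema, with a stated time of 1 h, at a dose of 100 mg/kg by the oral route (a higher number here means more inhibition at the dose given (going by the name of the read-out), a lower number less inhibition), where compound 3 gives 26.3%, the second highest of three numbers. Compound 1 `Cc1cc(-c2ccc(Cl)cc2)n(-c2ccc(S(=O)(=O)Nc3nccs3)cc2)n1` gives 34.1%, within the scatter of compound 3, while compound 2 `Cc1cc(C)n(Cc2n[nH]c(=S)o2)n1` gives 14.4%. For the measured compounds named here, the one step joining measured compounds, a number 11.9 percentage points higher from compound 2 to compound 3 (beyond the scatter), put phenyl in place of methyl on an aromatic carbon. Compound 4 `Cc1cc(-c2ccc(Cl)cc2)n(Cc2n[nH]c(=S)o2)n1` differs from compound 3 by chloro in place of hydrogen on an aromatic carbon. Going by the values given here, no measured step covers this change; compound 1 and compound 3 differ in more than one place and merely show two values within the scatter of each other. The step of a number 3.7 percentage points higher from compound 3 to compound 4 (within the scatter) is therefore expected to stay within the scatter. Compound 4 is estimated to give 30%, in a range from 17% to 45%.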

Compound 4, a percentage reported as inhibition, in the whole organism at one dose (the size of the read-out at that dose, not a potency): 15.4%
For compound 4 the middle estimate is 14.6 percentage points above the measured one; the whole stated range lies above it.
By their numbers in this assay, from the lowest: compounds 2 and 4 (each within the scatter of the next); then compounds 3 and 1 (each within the scatter of the next).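

In this assay, for the compounds shown here, the step of a number 10.9 percentage points lower from compound 3 to compound 4 (beyond the scatter) is the first measured change on the phenyl group, and it runs downward. Chloro in place of hydrogen on this aromatic carbon, para to a large group, therefore costs inhibition at the dose given, while the earlier step to phenyl had raised it. Nothing measured here explains this loss. From the compounds shown here alone, it remains open whether a different group at this place, such as methoxy, fluoro or an amine, would keep the number of compound 3.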